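A chloro for a methyl: what compound 3 may show

The source may report more compounds than this note shows. Statements on the series, on what has been measured and on what is new or still open speak of the compounds shown alone.

In a functional assay on T47D cells (Homo sapiens) for antiproliferative activity, read by MTT assay, with a stated time of 24 h (a higher number here means a weaker inhibitor, a lower number a stronger inhibitor), compound 2 `Cc1ccc(S(=O)(=O)Nc2ccc3cc[nH]c3c2)cc1` gives 57100 nM and compound 1 `O=S(=O)(Nc1ccc2cc[nH]c2c1)c1ccc(Br)cc1` gives 40100 nM, so the two stand within the scatter of each other. Compound 3 `O=S(=O)(Nc1ccc2cc[nH]c2c1)c1ccc(Cl)cc1` carries chloro in place of methyl on an aromatic carbon, para to a large group: chloro in place of methyl on an aromatic carbon. Among the compounds with values here, the one measured step at that place is methyl in place of bromo, a 1.4-fold higher number from compound 1 to compound 2 (0.15 log units; within the scatter), so no change beyond the scatter is expected in this assay. The estimated step is a 1.3-fold lower number from compound 2 to compound 3 (0.10 log units; within the scatter). For compound 3 the expected value is 45000 nM, within an estimated range of 25000 nM to 80000 nM.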

Compound 3, half-maximal inhibitory concentration: 46200 nM
Estimate against measurement, compound 3: 1.0-fold (0.01 log units) below; the measured number falls inside the stated range.
By their numbers in this assay, from the lowest: compounds 1, 3 and 2 (each within the scatter of the next).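

In this assay, chloro in place of methyl gives a 1.2-fold lower number from compound 2 to compound 3 (0.09 log units; within the scatter), and chloro in place of bromo gives a 1.2-fold higher number from compound 1 to compound 3 (0.06 log units; within the scatter). With a third group at this place, on an aromatic carbon para to a large group, methyl, bromo and chloro all stand within the scatter of one another, so these three compounds show no separation among the three groups. No measurement available here offers an explanation for this.

The compounds shown leave open whether an amine or a carboxylic acid at this place would move the number beyond the scatter.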